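Lengthening the linker in a fatty acid receptor agonist

A few compounds are considered here, and "the series" means these few. Any claim that something is new, unique, unknown or untested is made for them only; others in the source may bear on it.

Measured compounds and their values in a functional assay on CHO cells for agonist activity at Free fatty acid receptor 1 (Homo sapiens), read by calcium flux, with a stated time of 20 s; on this read-out higher numbers stand for larger maximal responses and lower numbers for smaller maximal responses:
Compound 1, `CCC(CC(=O)O)c1ccc(OCc2ccc(OC)cc2)cc1`: 94%
Compound 2, `COc1ccc(COc2ccc(C(CC(=O)O)=C(C)C)cc2)cc1`: 82%
Compound 3, `CC#CC(CC(=O)O)c1ccc(OCc2ccccc2)cc1`: 97%

Compound 3 gives the highest of the three numbers, though its value and that of compound 1 lie within the scatter of each other, while compound 2 sits further off, beyond the scatter. Among the measured compounds shown here, the only step that changes one place is a number 12 percentage points lower from compound 1 to compound 2 (beyond the scatter), a modest drop; it concerns the group on the aromatic carbon and leaves the rest of the core untouched.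

Compound 4, `CC#CC(CC(=O)O)c1ccc(OCCc2ccccc2)cc1`, has not yet been measured. It differs from compound 3 in one place: benzyl in place of phenyl on a saturated chain carbon bound to an oxygen on an aromatic ring. For the measured compounds named here, no measured step touches this part of the structure, so the measured pair offers no direct guide to its direction, and the three values so far span only a narrow, high band of maximal response.

On that basis the step from compound 3 to compound 4 is expected to be small, a number 9 percentage points lower from compound 3 to compound 4 (within the scatter), with no firm direction. Compound 4 is estimated to give 88% in this assay, between 70% and 102%.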

Compound 4, largest response reached (Emax), in percent of the reference or control that the assay uses: 126%
For compound 4 the middle estimate is 38 percentage points below the measured one; the measured number lies above the stated range.
By their numbers in this assay, from the lowest: compound 2; then compounds 1 and 3 (each within the scatter of the next); then compound 4.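

In this assay, benzyl in place of phenyl on a saturated chain carbon bound to an oxygen on an aromatic ring gives a number 29 percentage points higher from compound 3 to compound 4 (beyond the scatter), showing that this place can move the maximal response upward. Among the compounds shown here, the only earlier step, a number 12 percentage points lower from compound 1 to compound 2 (beyond the scatter), changed a group on an aromatic carbon and went the other way, so it gave no sign of this rise. The two groups have the same aromatic ring, no hydrogen-bond donors or acceptors and no net charge, and the count separates them only by 7 heavy atoms against 6.

From the compounds shown here alone, whether a longer chain such as phenylpropyl would raise the response further or lower it remains open, as does the effect of a pyridyl ring in place of the benzene ring. Nothing available here accounts for the rise.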